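Ortho-substituent swap in aryl urea series: chloro to bromo

A few compounds are considered here, and "the series" means these few. Any claim that something is new, unique, unknown or untested is made for them only; others in the source may bear on it.

Measured so far in an ADME assay on the whole organism with Oryza sativa as the target, tested at 1 uM; on this read-out lower numbers stand for a stronger effect and higher numbers for a weaker effect at the one concentration tested:
compound 1 `CC(C)c1ccccc1NC(=O)N[C@@H](C)c1ccccc1` gives 96%
compound 2 `COc1ccccc1NC(=O)N[C@@H](C)c1ccccc1` gives 99%
compound 3 `C[C@H](NC(=O)Nc1ccccc1Cl)c1ccccc1` gives 104%

Compound 3 carries the nominally highest of the three numbers, but the gaps a number 5 percentage points higher from compound 2 to compound 3 (within the scatter) and a number 8 percentage points higher from compound 1 to compound 3 (within the scatter) both lie within the scatter, so no ordering among the three can be read from these data.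

Compound 4 `C[C@H](NC(=O)Nc1ccccc1Br)c1ccccc1` has not been measured. The change from compound 3 is bromo in place of chloro on an aromatic carbon.

All three measured steps vary the group at this same aromatic carbon: a number 3 percentage points higher from compound 1 to compound 2 (within the scatter), a number 8 percentage points higher from compound 1 to compound 3 (within the scatter) and a number 5 percentage points higher from compound 2 to compound 3 (within the scatter). None of them moves the read-out beyond the scatter, although the exchanged groups differ considerably in kind. The swap of chloro for bromo is a smaller change than any of those. The expected outcome for compound 4 is therefore no movement beyond the scatter, a step of a number 2 percentage points lower from compound 3 to compound 4 (within the scatter).

The estimate for compound 4 in this assay is 102%, with a range from 91% to 113%.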

Compound 4, a percentage reported as activity, at one concentration (the size of the read-out at that concentration, not a potency): 99%
Estimate against measurement, compound 4: 3 percentage points above, within the range that was stated.
By their numbers in this assay, from the lowest: compounds 1, 2, 4 and 3 (each within the scatter of the next).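

In this assay the exchange of one halogen for another gives a number 5 percentage points lower from compound 3 to compound 4 (within the scatter) so a change of chloro to bromo on this aromatic carbon, ortho to a large group, stays within the scatter. Bromo also sits within the scatter of the two non-halogen groups, with no change at the digits printed from compound 2 to compound 4 (within the scatter) and a number 3 percentage points higher from compound 1 to compound 4 (within the scatter) as the remaining new steps, so isopropyl, methoxy, chloro and bromo at this carbon cannot be told apart on this read-out. Nothing available bears on why the read-out does not separate these groups.

Whether any group at this carbon can move the read-out beyond the scatter remains open, as an amine, a carboxylic acid or a longer chain has no value among the compounds shown. As far as these compounds go, all four compounds keep the rest of the core of compound 1 unchanged, so the effect of changes elsewhere on the core also remains open.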